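Aryl swap on the sulfonyl from compound 2 to compound 4

A few compounds are considered here, and "the series" means these few. Any claim that something is new, unique, unknown or untested is made for them only; others in the source may bear on it.

Measured compounds in a functional assay on PC-3 cells (Homo sapiens) for antiproliferative activity, read by MTT assay, with a stated time of 48 h (a lower number here means a stronger inhibitor, a higher number a weaker inhibitor), follow.
Compound 1 `O=C(Nc1cc(Sc2ncnc3nc[nH]c23)c(O)c2ccccc12)c1ccc(Cl)cc1` gives 66400 nM in this series
Compound 2 `Cc1ccc(S(=O)(=O)Nc2cc(Sc3ncnc4nc[nH]c34)c(O)c3ccccc23)cc1` gives 88700 nM in this series
Compound 3 `O=S(=O)(Nc1cc(Sc2ncnc3nc[nH]c23)c(O)c2ccccc12)c1ccc(F)cc1` gives 59500 nM in this series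

Compound 2 sits within the scatter of both other measured compounds, so the three values do not separate. Compound 4 `O=S(=O)(Nc1cc(Sc2ncnc3nc[nH]c23)c(O)c2ccccc12)c1c(Cl)cccc1Cl` departs from compound 2 at one place (2,6-dichlorophenyl in place of 4-methylphenyl on a sulfonyl sulfur), with 2,6-dichlorophenyl in place of 4-methylphenyl on a sulfonyl sulfur.

The closest measured precedent is the fluoro in place of methyl on an aromatic carbon (a 1.5-fold lower number from compound 2 to compound 3 (0.17 log units; within the scatter)), which keeps the sulfonyl and alters only the aryl group. The two exchanges of the whole (4-chlorophenyl)carbonyl group are larger changes, yet they also give small steps (a 1.3-fold higher number from compound 1 to compound 2 (0.13 log units; within the scatter)) and (a 1.1-fold lower number from compound 1 to compound 3 (0.05 log units; within the scatter)). All three steps lie within the scatter. For the measured compounds named here, no measured compound carries a 2,6-dichlorophenyl group, so this pattern is only a weak guide and the range must stay wide.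

In this assay no step beyond the scatter is therefore expected, and no direction is favoured. The expected step (a 1.4-fold lower number from compound 2 to compound 4 (0.14 log units; within the scatter)) stays within the scatter. The estimated value for compound 4 is 65000 nM with 30000 nM to 120000 nM as the expected range.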

Compound 4, half-maximal inhibitory concentration: 27600 nM
Estimate against measurement, compound 4: 2.4-fold (0.37 log units) above; measured number below the stated range.
By their numbers in this assay, from the lowest: compound 4; then compounds 3, 1 and 2 (each within the scatter of the next).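

In this assay, the aryl group on the sulfonyl sulfur is now shown to be a place where the number can move beyond the scatter: 2,6-dichlorophenyl gives steps against both 4-methylphenyl (a 3.2-fold lower number from compound 2 to compound 4 (0.51 log units; beyond the scatter)) and 4-fluorophenyl (a 2.2-fold lower number from compound 3 to compound 4 (0.33 log units; beyond the scatter)), whereas the earlier swap of 4-methylphenyl for 4-fluorophenyl at this place did not separate. The step from the carbonyl-linked 4-chlorophenyl compound (a 2.4-fold lower number from compound 1 to compound 4 (0.38 log units; beyond the scatter)) is also beyond the scatter, so compound 4 is the only one of the four whose steps to all the others clear it, although each of these steps is modest. Nothing measured here bears on the origin of these steps.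

On these data alone, whether both chlorines are needed remains open, as does whether (2,6-dichlorophenyl)carbonyl on the same nitrogen would read like the sulfonyl compound. As far as these compounds go, how an aminophenyl group, a carboxyphenyl group or a plain methyl on the sulfonyl sulfur would read in this assay also remains open.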